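Fluorophenyl isomers: from compound 3 to compound 4

The source may hold more compounds than are shown below. What is called first, only, known or untested is meant among the compounds shown, and "the series" means these compounds.

Values in a functional assay on A-375 cells (Homo sapiens) for cytotoxicity, read by CCK-8 assay, with a stated time of 24 h; on this read-out lower numbers stand for stronger inhibition and higher numbers for weaker inhibition:
compound 1 `COc1ccccc1Oc1c(N)nc(Cc2ccccc2)nc1OCCO`: 200 nM
compound 2 `COc1ccccc1Oc1c(N)nc(-c2ccc(C)cc2)nc1OCCO`: 2380 nM
compound 3 `COc1ccccc1Oc1c(N)nc(-c2cccc(F)c2)nc1OCCO`: 8530 nM

Among the three, compound 3 has the highest number, at 8530 nM. The next structure, compound 4 `COc1ccccc1Oc1c(N)nc(-c2ccc(F)cc2)nc1OCCO`, is an isomer of it: 4-fluorophenyl in place of 3-fluorophenyl on an aromatic carbon. The change is 4-fluorophenyl in place of 3-fluorophenyl on an aromatic carbon.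

Among the measured compounds shown here, no measured pair isolates this kind of change, so the evidence is indirect. The closest measured step is a 3.6-fold higher number from compound 2 to compound 3 (0.55 log units; beyond the scatter), which joins the two compounds without benzyl. The larger steps, a 12-fold higher number from compound 1 to compound 2 (1.08 log units; beyond the scatter) and a 43-fold higher number from compound 1 to compound 3 (1.63 log units; beyond the scatter), both start from benzyl, which compound 4 does not carry, so they say little about this change. The 4-methylphenyl of compound 2 is the nearest measured match to the entering 4-fluorophenyl, and the expectation of a lower number rests on compound 2 at 2380 nM. For the measured compounds named here, with only one such compound, that lean is weak.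

In this assay a small step toward a lower number is expected, a 1.9-fold lower number from compound 3 to compound 4 (0.28 log units; within the scatter). For compound 4 the estimated value is 4500 nM, with an expected range of 1500 nM to 12000 nM.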

Compound 4, half-maximal inhibitory concentration: 15900 nM
For compound 4 the middle estimate is 3.5-fold (0.55 log units) below the measured one, outside the stated range (above it).
By their numbers in this assay, from the lowest: compound 1; then compound 2; then compounds 3 and 4 (each within the scatter of the next).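

In this assay, moving the fluoro group from the 3-fluorophenyl to the 4-fluorophenyl on the aromatic carbon between two ring nitrogen atoms gives a 1.9-fold higher number from compound 3 to compound 4 (0.27 log units; within the scatter), so this pair of isomers does not separate at this position. The comparison with the 4-methylphenyl of compound 2 gives a 6.7-fold higher number from compound 2 to compound 4 (0.82 log units; beyond the scatter), which shows that fluoro in place of methyl on that phenyl ring matters more here than the placement of the fluoro group. The step from benzyl gives an 80-fold higher number from compound 1 to compound 4 (1.90 log units; beyond the scatter), and compound 1 now has steps beyond the scatter to all three directly attached substituted phenyl compounds, which leaves benzyl as the clear best of the four at this position.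

No measurement is available that accounts for any of these steps. On these data alone, it remains open whether the benzyl advantage survives on a 4-fluorobenzyl or 3-fluorobenzyl group, whether a longer chain such as 2-phenylethyl keeps or loses it, and whether an unsubstituted phenyl would sit with compound 1 or with compounds 2, 3 and 4.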